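The compounds below may be only part of what the source reports. "The series", "measured", "known", "first", "only" and "open" are said of these compounds alone.

Measured in a functional assay on MCF7 cells (Homo sapiens) for antiproliferative activity, read by sulforhodamine B assay, with a stated time of 48 h; a higher number here means a weaker inhibitor, a lower number a stronger inhibitor:
Compound 1 `COc1ccc(C=C(C(=O)/C=C/c2cccc(OC)c2OC)C(=O)/C=C/c2cccc(OC)c2OC)cc1OC`: 560 nM
Compound 2 `COc1cccc(/C=C/C(=O)C(=Cc2ccc(O)c(F)c2)C(=O)/C=C/c2cccc(OC)c2OC)c1OC`: 300 nM

Compound 2, at 300 nM, lies within the scatter of compound 1, so the two numbers set no order between them. Compound 3 `COc1cc(C=C(C(=O)/C=C/c2cccc(OC)c2OC)C(=O)/C=C/c2cccc(OC)c2OC)cc(OC)c1O` has not yet been measured. It carries 4-hydroxy-3,5-dimethoxyphenyl in place of 3-fluoro-4-hydroxyphenyl on a double-bonded chain carbon bound to a double-bonded chain carbon.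

Going by the values given here, only one measured step bears on this change, an exchange at the same place: a 1.9-fold lower number from compound 1 to compound 2 (0.27 log units; within the scatter). Among the compounds with values here, no measured compound yet shows how the entering group behaves, so this is a thin guide. A step beyond the scatter in this assay is therefore not expected, in either direction. The expected change is a 1.3-fold higher number from compound 2 to compound 3 (0.12 log units; within the scatter). Compound 3 is estimated at 400 nM, with an expected range from 150 nM to 1100 nM.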

Compound 3, half-maximal inhibitory concentration: 460 nM
Compound 3: the middle estimate sits 1.2-fold (0.06 log units) below what was measured, within the range that was stated.
By their numbers in this assay, from the lowest: compounds 2, 3 and 1 (each within the scatter of the next).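

In this assay, the place on a double-bonded chain carbon bound to a double-bonded chain carbon now holds a third group, and 4-hydroxy-3,5-dimethoxyphenyl in place of 3-fluoro-4-hydroxyphenyl gives a 1.5-fold higher number from compound 2 to compound 3 (0.19 log units; within the scatter). Set against 3,4-dimethoxyphenyl, the same entering group gives a 1.2-fold lower number from compound 1 to compound 3 (0.09 log units; within the scatter), so compounds 1, 2 and 3 carry three different groups here without any order being set among them, even though the entering group has more heavy atoms and hydrogen-bond acceptors than 3-fluoro-4-hydroxyphenyl. Nothing available offers an explanation for these numbers.

From the compounds shown here alone, what happens at this place with a group that has no aromatic ring, such as an amine, a carboxylic acid or a longer chain, remains open. Also open, going by these compounds, is whether these three groups stay this close outside this assay.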